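The source may hold more compounds than are shown below. What is called first, only, known or untested is meant among the compounds shown, and "the series" means these compounds.

Measured so far in a functional assay on DU-145 cells (Homo sapiens) for inhibition, read by MTT assay, with a stated time of 72 h; on this read-out higher numbers stand for weaker inhibition and lower numbers for stronger inhibition
- Compound 1 `O=C1C=C(N2CCN(c3ccc(Cl)cc3)CC2)C(=O)c2ccccc21` gives 29500 nM 
- Compound 2 `O=C1C=C(N2CCN(c3ccccc3Cl)CC2)C(=O)c2ccccc21` gives 2900 nM 

Compound 2 holds the lower of these two numbers, which makes it the stronger inhibitor of the pair. Compound 3 `COc1cccc(N2CCN(C3=CC(=O)c4ccccc4C3=O)CC2)c1` differs from compound 2 by one change 3-methoxyphenyl in place of 2-chlorophenyl on an amine nitrogen in a ring with 3-methoxyphenyl in place of 2-chlorophenyl on an amine nitrogen in a ring. Within the data shown here, the only measured step bearing on this is a 10-fold lower number from compound 1 to compound 2 (1.01 log units; beyond the scatter) and it is large, so the group at this place can matter. Neither measured compound carries a methoxy group, which leaves the estimate loose. For compound 3 the expected step is a 2.4-fold higher number from compound 2 to compound 3 (0.38 log units; beyond the scatter) in this assay toward weaker inhibition. Compound 3 is estimated at 7000 nM with an expected range from 2000 nM to 28000 nM in this read-out.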

Compound 3, half-maximal inhibitory concentration: 15000 nM
Compound 3: middle estimate off by 2.1-fold (0.33 log units), on the low side, within the range that was stated.
By their numbers in this assay, from the lowest: compound 2; then compounds 3 and 1 (each within the scatter of the next).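

Compound 2 keeps its lead when the 2-chlorophenyl group gives way to 3-methoxyphenyl in this assay (a 5.2-fold higher number from compound 2 to compound 3 (0.71 log units; beyond the scatter)). The comparison with the other chlorine compound (a 2.0-fold lower number from compound 1 to compound 3 (0.29 log units; within the scatter)) shows no separation between compound 1 and compound 3. So, among these three groups, only 2-chlorophenyl stands apart, and a group without chlorine can match 4-chlorophenyl within the scatter.

On these data alone, whether the chlorine or the place of attachment on the phenyl ring matters more stays open, and 2-methoxyphenyl or 3-chlorophenyl would help separate them. No supporting measurement explains these differences.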